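Adding a Phenyl to Compound 2: Expected Cytotoxicity

The compounds below may be only part of what the source reports. "The series", "measured", "known", "first", "only" and "open" are said of these compounds alone.

Compound 2 `COC(=O)c1ccc(NCc2cncn2Cc2ccccc2)cc1-c1ccccc1` was tested in a toxicity assay on NIH3T3 cells (Mus musculus) for cytotoxicity, read by resazurin assay; on this read-out lower numbers stand for an effect already at smaller amounts and higher numbers for an effect only at larger amounts of compound. In this assay compound 2 gives > 1000 nM, which is a limit of the assay and not a number. Compound 3 `COC(=O)c1ccc(NCc2cncn2Cc2ccc(N)cc2)cc1-c1ccccc1` differs from it by amino in place of hydrogen on an aromatic carbon; in this assay compound 3 gives > 10000 nM, again only a limit. The step that the two limits leave unreadable from compound 2 to compound 3 can therefore not be read. Compound 1 `CN(C)c1ccc(NCc2cncn2Cc2ccc(-c3ccccc3)cc2)cc1-c1ccccc1` also carries a 4-phenylphenyl group, and in this assay compound 1 gives > 1000 nM, once more a limit. Compound 4 `COC(=O)c1ccc(NCc2cncn2Cc2ccc(-c3ccccc3)cc2)cc1-c1ccccc1` arises from compound 2 by phenyl in place of hydrogen on an aromatic carbon. No readable step bears on this change, and every value shown is a limit: the limit of > 1000 nM in this assay, at which 2 of the 3 values shown sit, and (the limit of > 10000 nM in this assay, at which 1 of the 3 values shown sits). Compound 4 is therefore expected to remain weak in this assay, with an estimated 5000 nM between 1000 nM and 30000 nM. The step that the limit leaves unreadable from compound 2 to compound 4 that this estimate means is expected to lie within the scatter.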

Compound 4, half-maximal effective concentration: > 1000 nM
Compound 4: only a limit was reported; the forecaster's own chance of this, stated with the estimate: 80%; the middle value is on the limit's open side.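

In this assay, going by these compounds alone, compound 4 gives only a limit, as do compound 1, compound 2 and compound 3, so no step to compound 4 can be read. The compounds shown leave open at what concentration any of them becomes cytotoxic.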